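Amine-chain replacement in a tricyclic diamine series

A few compounds are considered here, and "the series" means these few. Any claim that something is new, unique, unknown or untested is made for them only; others in the source may bear on it.

Of the compounds shown here, three have been measured in an ADME assay on microsomes from liver (Homo sapiens) for metabolic stability, using NADPH, with a stated time of 10 min; on this read-out higher numbers stand for a more stable compound and lower numbers for a less stable compound. Compound 1 `NCCCCN(C[C@@H]1Cc2nccnc2CN1)[C@H]1CCCc2cccnc21` gives 87%. Compound 2 `NC/C=C/CN(C[C@H]1Cc2ncccc2CN1)[C@H]1CCCc2cccnc21` gives 85%, and compound 3 `CN(C)CCCCN(C[C@H]1Cc2ncccc2CN1)[C@H]1CCCc2cccnc21` gives 100%. Compound 2 sits at the low end of these three numbers: compound 1 lies within the scatter of it, while compound 3 lies beyond it, with a number 15 percentage points higher from compound 2 to compound 3 (beyond the scatter).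

Compound 4 `c1cnc2c(c1)CN[C@@H](CN(CCCCNC1COC1)[C@H]1CCCc3cccnc31)C2` is not yet measured. It differs from compound 2 by a group of 8 heavy atoms (6 carbon, 1 nitrogen, 1 oxygen; one four-membered non-aromatic ring with 1 hetero atom) in place of a group of 4 heavy atoms (3 carbon, 1 nitrogen; no ring), on a saturated chain carbon bound to an amine nitrogen. Going by the values given here, the only measured step that touches the same position is the one from compound 2 to compound 3, where the 3-aminoprop-1-en-1-yl group was also replaced, and which was modest and upward. Among the compounds with values here, the group that enters in compound 4 is larger and carries one four-membered non-aromatic ring with 1 hetero atom, so no measured step tells how far it will follow compound 3. The expectation for compound 4 is a small rise, possibly not beyond the scatter, which means a number 4 percentage points higher from compound 2 to compound 4 (within the scatter). Compound 4 is therefore estimated at 89%, in the range from 75% to 100%.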

Compound 4, percent of the compound remaining: 97%
Compound 4: middle estimate off by 8 percentage points, on the low side, and the stated range covers the measured number.
By their numbers in this assay, from the lowest: compounds 2, 1, 4 and 3 (each within the scatter of the next, the first and the last beyond it).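

With (oxetan-3-yl)amino at the chain end, this assay shows a number 12 percentage points higher from compound 2 to compound 4 (beyond the scatter) and so the upward step at this position is not limited to the dimethylamino group of compound 3. The larger group with its four-membered ring also costs nothing measurable against dimethylamino, with a number 3 percentage points lower from compound 3 to compound 4 (within the scatter) and so within the scatter, which means the two saturated-chain amines cannot be ranked in this read-out. Both replacements of the 3-aminoprop-1-en-1-yl group, on the core of compound 2, therefore stand beyond the scatter above it.

Open, on these data alone, is whether the saturated chain alone accounts for the step, which a plain primary amine at the end of the saturated chain on this same core would separate from the effect of substituting that nitrogen, and how a longer chain or a morpholine at this position would read. Nothing available explains why these numbers differ.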